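The source may report more compounds than this note shows. Statements on the series, on what has been measured and on what is new or still open speak of the compounds shown alone.

Compound 1 `O=C1CC(c2nc(-c3cccc(Cl)c3)no2)CN1c1ccc(Cl)c(Cl)c1` stands lowest of the three compounds measured in an in vitro functional assay on HEK293-A cells for positive allosteric modulation of metabotropic glutamate receptor 5 (Homo sapiens), read by FLIPR and calcium flux (a lower number here means that less compound is needed, a higher number that more compound is needed for the effect), giving 460 nM. Compound 2 `O=C1CC(c2nc(-c3ccc(F)cc3)no2)CN1c1ccc(Cl)c(Cl)c1` gives 2300 nM and compound 3 `O=C1CC(c2nc(-c3cccc(F)c3)no2)CN1c1ccc(Cl)c(Cl)c1` gives 3200 nM; the steps of a 5.0-fold higher number from compound 1 to compound 2 (0.70 log units; beyond the scatter) and a 7.0-fold higher number from compound 1 to compound 3 (0.84 log units; beyond the scatter) lie beyond the scatter, while a 1.4-fold higher number from compound 2 to compound 3 (0.14 log units; within the scatter) lies within it. Compound 4 `Cc1ccc(N2CC(c3nc(-c4cccc(Cl)c4)no3)CC2=O)cc1C` differs from compound 1 as 3,4-dimethylphenyl in place of 3,4-dichlorophenyl on an amide-type nitrogen in a ring. For the measured compounds named here, none of the measured steps touches this ring; each of them changes the other aromatic ring, so there is no direct guide for this swap, and a change of modest size in either direction cannot be ruled out. The step expected is a 2.2-fold higher number from compound 1 to compound 4 (0.34 log units; beyond the scatter). Compound 4 is estimated to give 1000 nM, with a range from 300 nM to 4000 nM.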

Compound 4, half-maximal effective concentration: 310 nM
Beside the measured number, compound 4's estimate is 3.2-fold (0.51 log units) above it, and the stated range covers the measured number.
By their numbers in this assay, from the lowest: compounds 4 and 1 (each within the scatter of the next); then compounds 2 and 3 (each within the scatter of the next).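

In this assay, 3,4-dimethylphenyl can replace 3,4-dichlorophenyl on the amide-type nitrogen with a 1.5-fold lower number from compound 1 to compound 4 (0.17 log units; within the scatter) and no real change in the number. For the compounds shown here, this is the first view of this position, and here two methyl groups serve as well as two chlorines, whereas the fluorine changes on the other aromatic ring in compound 2 and compound 3 raised the number beyond the scatter. Nothing available explains why this swap leaves the number unmoved.

Still open, as far as these compounds go, is whether this position accepts groups unlike both, such as a methoxy group, an amine or a carboxylic acid. Also open, from the compounds shown here alone, is whether a plain phenyl ring, with neither chlorines nor methyl groups, would hold the number.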